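The source may report more compounds than this note shows. Statements on the series, on what has been measured and on what is new or still open speak of the compounds shown alone.

Of the compounds shown here, three sharing one core have been measured in an assay on CHO cells for displacement of a labelled ligand from Alpha-2C adrenergic receptor (Homo sapiens); on this read-out lower numbers stand for stronger inhibition and higher numbers for weaker inhibition. Compound 1 `CC(Oc1ccccc1-c1cccnc1)C1=NCCN1` gives 64.6 nM. Compound 2 `CC(Oc1ccccc1-c1ccncc1)C1=NCCN1` gives 1450 nM, and compound 3 `Cc1ccccc1-c1ccccc1OC(C)C1=NCCN1` gives 234 nM. Compound 3 therefore stands second highest of the three numbers: compound 1 lies closest, with a 3.6-fold higher number from compound 1 to compound 3 (0.56 log units; beyond the scatter), while compound 2 lies furthest, with a 6.2-fold lower number from compound 2 to compound 3 (0.79 log units; beyond the scatter). The step to compound 4 `CC(Oc1ccccc1-c1ccccn1)C1=NCCN1` is pyridin-2-yl in place of 2-methylphenyl on an aromatic carbon. Among the compounds with values here, no measured step involves pyridin-2-yl, so the only guides are the two modest steps just named and the step of a 22-fold higher number from compound 1 to compound 2 (1.35 log units; beyond the scatter), which shows that exchanging one pyridinyl group for another can move this assay a great deal in either direction. With one pyridinyl group giving a clearly lower number than compound 3 and the other a clearly higher one, a middle course is the most defensible expectation. Compound 4 is therefore expected to land near 150 nM, within a broad range from 35 nM to 700 nM. That estimate means a 1.6-fold lower number from compound 3 to compound 4 (0.19 log units; within the scatter), a step expected to stay within the usual scatter.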

Compound 4, inhibition constant: 1260 nM
The estimate for compound 4 lay 8.4-fold (0.92 log units) below the measured number; measured number outside the range, above it.
By their numbers in this assay, from the lowest: compound 1; then compound 3; then compounds 4 and 2 (each within the scatter of the next).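

In this assay, putting pyridin-2-yl in place of 2-methylphenyl gives a 5.4-fold higher number from compound 3 to compound 4 (0.73 log units; beyond the scatter) and shows that a pyridinyl group at this position does not by itself lower the number. Of the three pyridinyl groups, only pyridin-3-yl gives a low number: pyridin-2-yl in its place gives a 20-fold higher number from compound 1 to compound 4 (1.29 log units; beyond the scatter) while pyridin-2-yl and pyridin-4-yl cannot be told apart, with a 1.2-fold lower number from compound 2 to compound 4 (0.06 log units; within the scatter) as their step. The outcome therefore depends on where the nitrogen sits in the pyridinyl ring, and nothing available explains this.

Still open, going by these compounds, is whether adding a methyl or methoxy group to the pyridin-3-yl ring would keep the low number of compound 1. Also open, on these data alone, is how a plain phenyl ring or a non-aromatic amine would fare at this position.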